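The source may hold more compounds than are shown below. What is called first, only, known or untested is meant among the compounds shown, and "the series" means these compounds.

The series shares one core, seen in compound 1 `CCCC(=O)Nc1ccn([C@@H]2CO[C@H](CO)O2)c(=O)n1` and compound 2 `CCCCCCC(=O)Nc1ccn([C@@H]2CO[C@H](CO)O2)c(=O)n1`, and differs only in the group attached to the amide carbonyl. In a functional assay on A549 cells (Homo sapiens) for cytotoxicity, read by sulforhodamine B assay, with a stated time of 72 h (a lower number here means a stronger inhibitor, a higher number a weaker inhibitor), compound 1 gives 6600 nM, while compound 2 gives 1040 nM. Among the measured compounds shown here, the single measured step is a 6.3-fold lower number from compound 1 to compound 2 (0.80 log units; beyond the scatter), a change that stands beyond the scatter. For the measured compounds named here, compound 2 therefore holds the lowest number of the two measured so far, with compound 1 as its only neighbour at a higher value.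

Compound 3 `O=C(Nc1ccn([C@@H]2CO[C@H](CO)O2)c(=O)n1)c1ccc(F)cc1` is not yet measured. It departs from compound 2 by 4-fluorophenyl in place of hexyl on a carbonyl carbon. Going by the values given here, the step from compound 1 to compound 2 bears on this only loosely: it shows that a longer saturated chain on the carbonyl lowered the number, but no measured compound carries a ring at that position, so the effect of an aromatic group is unknown here. Given that gap, compound 3 is expected to land near the two measured values, with a modest upward shift from compound 2 as the more likely outcome, a 2.9-fold higher number from compound 2 to compound 3 (0.46 log units; beyond the scatter). In this assay compound 3 is estimated at 3000 nM, with a range from 800 nM to 12000 nM.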

Compound 3, half-maximal inhibitory concentration: 8670 nM
For compound 3 the middle estimate is 2.9-fold (0.46 log units) below the measured one; measured number inside the range.
By their numbers in this assay, from the lowest: compound 2; then compounds 1 and 3 (each within the scatter of the next).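

At the carbonyl carbon, the result gives the first view of a ring in this place: in this assay, 4-fluorophenyl in place of hexyl gives an 8.3-fold higher number from compound 2 to compound 3 (0.92 log units; beyond the scatter), so this aromatic group does not keep the lower number seen with hexyl. Set against the shorter chain, the change gives a 1.3-fold higher number from compound 1 to compound 3 (0.12 log units; within the scatter), which lies within the scatter, so compound 3 and compound 1 cannot be told apart in this assay. The heavy-atom count of the group therefore does not by itself set the number at this place, since 4-fluorophenyl has more heavy atoms than hexyl, yet compound 3 stands with compound 1, the propyl compound, and not with compound 2.

The compounds shown leave open whether the fluorine or the aromatic ring accounts for the loss relative to hexyl, a question that a plain phenyl group would address, and whether a longer chain than hexyl would lower the number further. Nothing available here gives an independent measurement that accounts for these differences in the cytotoxicity read-out.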